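A few compounds are considered here, and "the series" means these few. Any claim that something is new, unique, unknown or untested is made for them only; others in the source may bear on it.

Working notes on the series. The shared core carries an amino group on the aromatic ring; three compounds with different substituents on that nitrogen have been measured. Compound 1 `CCNc1nc(-c2ccccc2)nc2c1nnn2Cc1ccccc1` gives 91 nM in an assay on Cerebral cortex for displacement of a labelled ligand from adenosine receptor A1 (Bos taurus); a lower number here means a stronger inhibitor, a higher number a weaker inhibitor. Compound 2 `CCCCNc1nc(-c2ccccc2)nc2c1nnn2Cc1ccccc1` gives 11 nM, and compound 3 `c1ccc(Cn2nnc3c(NC4CC4)nc(-c4ccccc4)nc32)cc1` gives 11.3 nM. Compound 3 thus sits with the better pair: its number is indistinguishable from that of compound 2, as the step of a 1.0-fold higher number from compound 2 to compound 3 (0.01 log units; within the scatter) shows, while the step of an 8.1-fold lower number from compound 1 to compound 3 (0.91 log units; beyond the scatter) sets it well apart from compound 1.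

Compound 4 `OCCNc1nc(-c2ccccc2)nc2c1nnn2Cc1ccccc1` is the next member. Its change from compound 3 is 2-hydroxyethyl in place of cyclopropyl on a nitrogen on an aromatic ring; cut one bond further out, the change reads cyclopropylamino to (2-hydroxyethyl)amino. Going by the values given here, the steps that bear on it are an 8.1-fold lower number from compound 1 to compound 3 (0.91 log units; beyond the scatter) and an 8.3-fold lower number from compound 1 to compound 2 (0.92 log units; beyond the scatter): both show that a small ethyl on this nitrogen gives the weakest number of the three, and that either a longer chain or a small ring recovers the loss. Among the compounds with values here, the entering group is a two-carbon chain like ethyl with a hydroxyl at its end; no measured step introduces a hydroxyl here, so the hydroxyl itself is an unknown. Compound 4 is therefore expected to move back toward compound 1, a step of roughly a 13-fold higher number from compound 3 to compound 4 (1.12 log units; beyond the scatter), and its estimated value is 150 nM with a range from 40 nM to 600 nM.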

Compound 4, inhibition constant: 38 nM
Compound 4: middle estimate off by 3.9-fold (0.60 log units), on the high side; the whole stated range lies above it.
By their numbers in this assay, from the lowest: compounds 2 and 3 (each within the scatter of the next); then compound 4; then compound 1.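

In this assay the first hydroxyl at this nitrogen does not cost affinity relative to the plain two-carbon chain: 2-hydroxyethyl gives a lower number than ethyl (a 2.4-fold lower number from compound 1 to compound 4 (0.38 log units; beyond the scatter)), a step beyond the scatter that the earlier compounds could not have shown. The gain is only partial, since 2-hydroxyethyl stays behind both cyclopropyl (a 3.4-fold higher number from compound 3 to compound 4 (0.53 log units; beyond the scatter)) and the longer chain of compound 2 (a 3.5-fold higher number from compound 2 to compound 4 (0.54 log units; beyond the scatter)), so among the four groups on this nitrogen it takes a middle place, above ethyl and short of the two groups that are within the scatter of each other. No measurement accompanies these values that would account for this order.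

The compounds shown leave open whether the gain over ethyl belongs to the hydroxyl itself or would persist with a methoxy or an amine at the end of the same two-carbon chain. They also leave open whether a hydroxyl at the end of a longer chain, such as a butyl chain, or on a cyclopropylmethyl group would keep the lower numbers of compound 2 and compound 3.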